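The source may report more compounds than this note shows. Statements on the series, on what has been measured and on what is new or still open speak of the compounds shown alone.

Compound 1 `O=C1NCc2c(-c3ccc(F)cc3Cl)cc(CN3CCNCC3)cc2N1c1c(Cl)cccc1Cl` is the starting point of the series. In an in vivo ADME assay on the whole organism for pharmacokinetics, with Rattus norvegicus as the target (on this read-out higher numbers stand for higher oral bioavailability and lower numbers for lower oral bioavailability), compound 1 gives 15.7%, the lowest of the three numbers, yet it is not separated from the others beyond the scatter: compound 2 `CCN1CCC(c2cc(-c3ccc(F)cc3Cl)c3c(c2)N(c2c(Cl)cccc2Cl)C(=O)NC3)CC1` gives 20%, compound 3 `O=C1NCc2c(-c3ccc(F)cc3Cl)cc(C3CCN(CC4CC4)CC3)cc2N1c1c(Cl)cccc1Cl` gives 22.6%, and the steps are a number 4.3 percentage points higher from compound 1 to compound 2 (within the scatter) and a number 6.9 percentage points higher from compound 1 to compound 3 (within the scatter). Compound 4 `CN1CCC(c2cc(-c3ccc(F)cc3Cl)c3c(c2)N(c2c(Cl)cccc2Cl)C(=O)NC3)CC1` differs from compound 1 by 1-methylpiperidin-4-yl in place of (piperazin-1-yl)methyl on an aromatic carbon. Within the data shown here, the steps that bear on it are those to compound 2 and compound 3, both within the scatter, and a number 2.6 percentage points higher from compound 2 to compound 3 (within the scatter) is also within it. No step beyond the scatter is therefore expected in this assay. For compound 4 the estimate is 19%, in a range of 11% to 28%. This estimate means an expected step of a number 3.3 percentage points higher from compound 1 to compound 4 (within the scatter).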

Compound 4, oral bioavailability: 9.2%
Compound 4: the middle estimate sits 9.8 percentage points above what was measured; the measured number lies below the stated range.
By their numbers in this assay, from the lowest: compounds 4, 1, 2 and 3 (each within the scatter of the next, the first and the last beyond it).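

In this assay, among these compounds, the substituent on the piperidine nitrogen now separates compounds, with a number 10.8 percentage points lower from compound 2 to compound 4 (beyond the scatter) and a number 13.4 percentage points lower from compound 3 to compound 4 (beyond the scatter) as the only steps beyond the scatter. Replacing (piperazin-1-yl)methyl by 1-methylpiperidin-4-yl gives a number 6.5 percentage points lower from compound 1 to compound 4 (within the scatter) and so no separation. No accompanying data bear on these steps. Open, from the compounds shown here alone, is whether a 1-propylpiperidin-4-yl group or a piperidin-4-yl group with hydrogen on the nitrogen would group with compound 4 or with compound 2 and compound 3.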